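Pyridyl isomers on the shared core: compound 4 expected

The source may report more compounds than this note shows. Statements on the series, on what has been measured and on what is new or still open speak of the compounds shown alone.

Compound 1 `Oc1cccc(-c2cc(-c3ccc(Cl)cc3)nc(-c3ccccn3)c2)c1` carries pyridin-2-yl on the shared core, and in a functional assay on T47D cells (Homo sapiens) for cytotoxicity, read by CCK-8 assay and cell counting, with a stated time of 2 days (a higher number here means a weaker inhibitor, a lower number a stronger inhibitor), compound 1 gives 13900 nM. Compound 3 `Oc1cccc(-c2cc(-c3ccc(Cl)cc3)nc(-c3cccnc3)c2)c1` carries pyridin-3-yl in its place; in this assay compound 3 gives 18100 nM. The step of a 1.3-fold higher number from compound 1 to compound 3 (0.11 log units; within the scatter) lies within the scatter, so these two numbers cannot be told apart. Compound 2 `Oc1ccc(-c2cc(-c3ccncc3)nc(-c3ccc(Cl)cc3)c2)cc1`, a relative with the hydroxyphenyl arranged differently, has no result in this assay "not determined" (no result reported). Within the data shown here, compound 3 therefore stands alongside compound 1 as one of only two numbers, with nothing beyond the scatter separating them.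

Compound 4 `Oc1cccc(-c2cc(-c3ccncc3)nc(-c3ccc(Cl)cc3)c2)c1` differs from compound 3 by pyridin-4-yl in place of pyridin-3-yl on an aromatic carbon. Among the measured compounds shown here, the one measured step that bears on this change, a 1.3-fold higher number from compound 1 to compound 3 (0.11 log units; within the scatter), moved the ring nitrogen of the same substituent and stayed within the scatter. A second move of that nitrogen is therefore expected to give no step beyond the scatter, in either direction. In this assay compound 4 is expected to give about 20000 nM, with a range from 8000 nM to 50000 nM. For the measured compounds named here, the expected step of a 1.1-fold higher number from compound 3 to compound 4 (0.04 log units; within the scatter) is an estimate that rests on the single related step, and the scatter of repeated measurements dominates it.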

Compound 4, half-maximal inhibitory concentration: 3330 nM
For compound 4 the middle estimate is 6.0-fold (0.78 log units) above the measured one; the measured number lies below the stated range.
By their numbers in this assay, from the lowest: compound 4; then compounds 1 and 3 (each within the scatter of the next).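

Notes on the pyridyl position: in this assay this position on the shared core does respond to where the ring nitrogen sits, which the pair of compound 1 and compound 3 could not show. Moving to pyridin-4-yl gives a 5.4-fold lower number from compound 3 to compound 4 (0.74 log units; beyond the scatter) and a 4.2-fold lower number from compound 1 to compound 4 (0.62 log units; beyond the scatter), both modest in size but beyond the scatter, so compound 4 is separated from both isomers while those two remain within the scatter of each other. The three compounds have the same atoms joined differently, so the difference in the numbers goes with the connectivity of this one ring alone, and nothing shown here offers a measurement that would explain it.

From the compounds shown here alone, what a plain phenyl, or a pyridin-4-yl ring bearing an amine or a carboxylic acid, would give at this position remains open. Also open, going by these compounds, is whether the step to pyridin-4-yl carries over when the hydroxyphenyl or the 4-chlorophenyl group on the shared core is changed, as the three numbers all come from a single arrangement of those groups.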